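Methoxymethyl on the pyridyl ring: compound 2 to compound 3

This account rests on a few compounds, and the source may have more. Where it says the series, first, only, none or still open, it means among the compounds named here.

Of the compounds shown here, two have been measured in an assay on T-REx-293 cells for inhibition of potassium channel subfamily T member 1 (Homo sapiens), read by patch clamp; a higher number here means a weaker inhibitor, a lower number a stronger inhibitor. Compound 1 `C[C@H](NC(=O)c1cc(C2CC2)nn1C)c1nc(-c2ccccc2)no1` gives 11400 nM. Compound 2 `C[C@H](NC(=O)c1cc(C(F)(F)F)nn1C)c1nc(-c2ccncc2)no1` gives 5250 nM, the lower of the two numbers, and its gap to compound 1 lies beyond the usual scatter, so compound 2 is the stronger inhibitor of the pair. Compound 1 and compound 2 differ in more than one place, so no single step can be read from them.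

Compound 3 `COCc1cc(-c2noc([C@H](C)NC(=O)c3cc(C(F)(F)F)nn3C)n2)ccn1` is not yet measured. It differs from compound 2 as follows: methoxymethyl in place of hydrogen on an aromatic carbon. Within the data shown here, no measured pair shows what this change does in this assay, so the direction of the step is open. The expected step, a 1.3-fold lower number from compound 2 to compound 3 (0.12 log units; within the scatter), is small, within or near the scatter. Compound 3 is expected to give 4000 nM, with a range from 1500 nM to 12000 nM.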

Compound 3, half-maximal inhibitory concentration: 322 nM
Beside the measured number, compound 3's estimate is 12-fold (1.09 log units) above it; measured number outside the range, below it.
By their numbers in this assay, from the lowest: compound 3; then compound 2; then compound 1.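

In this assay, among these compounds, the first single-place step is large: a 16-fold lower number from compound 2 to compound 3 (1.21 log units; beyond the scatter), as pyridin-4-yl becomes 2-(methoxymethyl)pyridin-4-yl. This shows that the aromatic carbon next to the ring nitrogen is not a silent position, since methoxymethyl there moves the number well beyond the scatter. Nothing available bears on the reason for this step.

The compounds shown hold only methoxymethyl at this position, so they do not separate the part played by its oxygen from that of the chain itself; a plain ethyl group, a hydroxymethyl group or a longer ether chain such as methoxyethyl would help to separate them. They also leave open whether an amine such as aminomethyl would give a similar step, and whether the step carries over to the core of compound 1.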